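Replacing chloro with methyl in compound 2

The source may report more compounds than this note shows. Statements on the series, on what has been measured and on what is new or still open speak of the compounds shown alone.

In a functional assay on MCF7 cells (Homo sapiens) for inhibition, read by MTT assay, with a stated time of 48 h (a lower number here means a stronger inhibitor, a higher number a weaker inhibitor), compound 1 (`O=C(C=CNc1cc(-c2ccccc2)nn1-c1ccccc1)c1cccs1`) gives 15400 nM and compound 2 (`O=C(C=CNc1cc(-c2ccccc2)nn1-c1ccccc1)c1ccc(Cl)cc1`) gives 8070 nM, so these two values lie within the usual scatter of each other. Compound 3 (`Cc1ccc(C(=O)C=CNc2cc(-c3ccccc3)nn2-c2ccccc2)cc1`) differs from compound 2 in one place: methyl in place of chloro on an aromatic carbon, with methyl in place of chloro on an aromatic carbon. For the measured compounds named here, the only measured step, a 1.9-fold lower number from compound 1 to compound 2 (0.28 log units; within the scatter), involves a different swap and stays within the scatter. Going by the values given here, no measured step covers this exact change, so no shift beyond the scatter is expected. The estimated step is a 1.2-fold higher number from compound 2 to compound 3 (0.09 log units; within the scatter). Compound 3 is expected at 10000 nM, with an estimated range of 4000 nM to 25000 nM.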

Compound 3, half-maximal inhibitory concentration: 30200 nM
Compound 3: the middle estimate sits 3.0-fold (0.48 log units) below what was measured; measured number outside the range, above it.
By their numbers in this assay, from the lowest: compounds 2, 1 and 3 (each within the scatter of the next, the first and the last beyond it).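

For the compounds shown here, at this ring position, para to a large group, a change of one heavy atom is enough to register: in this assay, methyl in place of chloro gives a 3.7-fold higher number from compound 2 to compound 3 (0.57 log units; beyond the scatter), the first step in this set beyond the scatter, though a modest one. By contrast, 4-methylphenyl in place of thiophen-2-yl gives a 2.0-fold higher number from compound 1 to compound 3 (0.29 log units; within the scatter), which stays within the scatter. Nothing available explains the gap between chloro and methyl. From the compounds shown here alone, how a methoxy group, an amine or a carboxylic acid at this position would read remains open.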